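A few compounds are considered here, and "the series" means these few. Any claim that something is new, unique, unknown or untested is made for them only; others in the source may bear on it.

Three compounds have been measured so far in a functional assay on the whole organism (strain albino) for inhibition, with Rattus norvegicus as the target, read by paw edema, with stated times of 30 min and 1 h, at a dose of 0.28 mmol/kg by the oral route; on this read-out lower numbers stand for less inhibition and higher numbers for more inhibition at the one dose given (going by the name of the read-out):

Compound 1, `COc1cc(-c2nnc(SCC(=O)Nc3ccc(/C(C)=N/O)cc3)n2-c2ccccc2)cc(OC)c1OC`, gives 59%.
Compound 2, `CCn1c(SCC(=O)Nc2ccc(C(C)=O)cc2)nnc1-c1ccc(OC)c(OC)c1`, gives 56%.
Compound 3, `COc1ccc(-c2nnc(SCC(=O)Nc3ccc(/C(C)=N/O)cc3)n2-c2ccccc2)cc1OC`, gives 57%.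

Compound 1 and compound 3 differ in a single place, (hydrogen in place of methoxy on an aromatic carbon), and the step between them is a number 2 percentage points lower from compound 1 to compound 3 (within the scatter). Compound 2 carries a different core from compound 1; the difference between the two cores is not broken down here, and the values of compound 2 and compound 3 lie within the scatter of each other, so nothing can be said about their order.

Compound 4, `CCn1c(SCC(=O)Nc2ccc(C(C)=O)cc2)nnc1-c1ccc(OC)cc1`, has not yet been measured. It is made from compound 2 by the change (hydrogen in place of methoxy on an aromatic carbon). Within the data shown here, this is the same kind of change as the one from compound 1 to compound 3, but not the same: in compound 1 the place is also meta to a methoxy group, whereas in compound 2 it is not. Because the earlier step of a number 2 percentage points lower from compound 1 to compound 3 (within the scatter) stayed within the scatter, a similarly small step is expected here, a number 2 percentage points lower from compound 2 to compound 4 (within the scatter). For compound 4 the value expected in this assay is 54%, most likely between 44% and 64%.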

Compound 4, a percentage reported as inhibition, in the whole organism at one dose (the size of the read-out at that dose, not a potency): 51%
Estimate against measurement, compound 4: 3 percentage points above; measured number inside the range.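

In this assay, replacing a methoxy group with hydrogen, which turns 3,4-dimethoxyphenyl into 4-methoxyphenyl, gives a number 5 percentage points lower from compound 2 to compound 4 (within the scatter). Set beside the earlier pair, the change shows no measurable difference between the two cores: the same change on two cores in this assay, a number 2 percentage points lower (within the scatter) from compound 1 to compound 3 and a number 5 percentage points lower (within the scatter) from compound 2 to compound 4, 3 percentage points apart, within the scatter of two such steps. This shows that on neither core does the change produce a step larger than the usual scatter, but it does not show that the change has no effect or that its effect is identical on both cores, and two pairs at one dose are too few to make a rule for the whole series.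

The compounds shown leave open whether a different group at this place on the ring, such as an amine or a carboxylic acid, would shift the value beyond the scatter. They also leave open whether the same holds for the loss of both methoxy groups, or for a longer chain such as butyl on the core of compound 2.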